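This account rests on a few compounds, and the source may have more. Where it says the series, first, only, none or still open, it means among the compounds named here.

Compound 3 `Cc1ccc(O)c(C(=O)c2cccnc2)c1`: 10000 nM
Compound 1 `O=C(c1cccnc1)c1cc(Cl)ccc1O`: 24800 nM
Compound 2 `C=CCOc1ccc(Br)cc1C(=O)c1cccnc1`: 59000 nM

In a functional assay on PC-3 cells (Homo sapiens) for cytotoxicity, read by sulforhodamine B assay, with a stated time of 48 h (on this read-out lower numbers stand for stronger inhibition and higher numbers for weaker inhibition), compound 3 gives the lowest of the three numbers shown; compound 1 lies somewhat higher, and compound 2, which carries bromo together with an allyl ether in place of the hydroxy group, higher still. Compound 4 `O=C(c1cccnc1)c1cc(Br)ccc1O` differs from compound 3 by bromo in place of methyl on an aromatic carbon. Going by the values given here, the one measured step that bears on this exchange runs in the opposite sense, a 2.5-fold lower number from compound 1 to compound 3 (0.39 log units; beyond the scatter), where a halogen gave way to methyl. Putting a halogen back, now bromo instead of chloro, a modest rise in the number is therefore expected, roughly to the level of compound 1. Compound 4 is estimated at 25000 nM with a range from 10000 nM to 60000 nM. The expected step is a 2.5-fold higher number from compound 3 to compound 4 (0.40 log units; beyond the scatter).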

Compound 4, half-maximal inhibitory concentration: 60200 nM
Compound 4: the middle estimate sits 2.4-fold (0.38 log units) below what was measured; measured number outside the range, above it.
By their numbers in this assay, from the lowest: compound 3; then compound 1; then compounds 2 and 4 (each within the scatter of the next).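

At the aromatic carbon para to the hydroxy group, this assay separates all three groups shown: a 2.4-fold higher number from compound 1 to compound 4 (0.39 log units; beyond the scatter) comes with bromo in place of chloro, and a 6.0-fold higher number from compound 3 to compound 4 (0.78 log units; beyond the scatter) comes with bromo in place of methyl, so the numbers rise from methyl through chloro to bromo. With bromo present, a 1.0-fold higher number from compound 2 to compound 4 (0.01 log units; within the scatter) comes with hydrogen in place of allyl on the oxygen, so the free hydroxy group and the allyl ether read alike here. Still open, from the compounds shown here alone, is how fluoro, methoxy or an amine at that carbon would read. Nothing shown gives a measured reason for these differences.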